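Capping the Aniline Nitrogen of Compound 2

A few compounds are considered here, and "the series" means these few. Any claim that something is new, unique, unknown or untested is made for them only; others in the source may bear on it.

In a functional assay on HeLa cells (Homo sapiens) for inhibition, read by cell counting, with a stated time of 4 days (a lower number here means a stronger inhibitor, a higher number a weaker inhibitor), compound 2 `COc1ccc(-c2csc3nc(-c4cccc(N)c4)cn23)cc1` gives 19000 nM, the lowest of the two numbers at hand, while compound 1 `Nc1cccc(-c2cn3c(-c4ccccc4)csc3n2)c1` gives 60000 nM. Going by the values given here, the one measured step, a 3.2-fold lower number from compound 1 to compound 2 (0.50 log units; beyond the scatter), is methoxy in place of hydrogen on an aromatic carbon. Compound 3 `C=C(Br)C(=O)Nc1cccc(-c2cn3c(-c4ccc(OC)cc4)csc3n2)c1` keeps that methoxy and differs from compound 2 at the amino nitrogen: (1-bromoethenyl)carbonyl in place of hydrogen on a nitrogen on an aromatic ring. Among the compounds with values here, no measured step touches this nitrogen, so the step from compound 1 to compound 2 does not bear on the change, and the expectation rests on the number for compound 2 together with an untested substitution. The account therefore expects a modest lowering of the number, a 2.4-fold lower number from compound 2 to compound 3 (0.38 log units; beyond the scatter), with a wide band around it. Compound 3 is estimated at 8000 nM, within a range of 1500 nM to 40000 nM.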

Compound 3, half-maximal inhibitory concentration: 860 nM
For compound 3 the middle estimate is 9.3-fold (0.97 log units) above the measured one, outside the stated range (below it).
By their numbers in this assay, from the lowest: compound 3; then compound 2; then compound 1.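

Compound 3 shows that the amino nitrogen, which the earlier step left untouched, is a place where the number in this assay can move a long way: the change to ((1-bromoethenyl)carbonyl)amino gives a large step (a 22-fold lower number from compound 2 to compound 3 (1.34 log units; beyond the scatter)). This step is graded large, whereas the methoxy change on the other side of the compound is graded modest (a 3.2-fold lower number from compound 1 to compound 2 (0.50 log units; beyond the scatter)), so the nitrogen tolerates a capping group and the lowering there is the bigger of the two. Nothing measured here accounts for the size of this step.

The carbonyl, the double bond and the bromine all enter together, so the compounds shown leave open which of them carries the step, a question that a plain acetyl or propanoyl group on this nitrogen would address. Also open, from the compounds shown here alone, is whether the same capping group gives a similar step on the core of compound 1, which lacks the methoxy.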